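Removing the Amino Group from Compound 1

This account rests on a few compounds, and the source may have more. Where it says the series, first, only, none or still open, it means among the compounds named here.

Measured so far:
compound 1, `Nc1nnc(-c2csc(-c3ccccc3)n2)o1`: 18.2%
compound 2, `Nn1c(-c2csc(-c3ccccc3)n2)n[nH]c1=O`: 15.2%

In a functional assay on the whole organism (strain Wistar albino) for inhibition, with Rattus norvegicus as the target, read by paw edema, with a stated time of 1 h, at a dose of 25 mg/kg by the oral route (a lower number here means less inhibition, a higher number more inhibition at the dose given (going by the name of the read-out)), compound 1 gives 18.2%, the higher of the two numbers, yet compound 2 with 15.2% lies within the scatter of it, so no order between them can be claimed. Compound 3, `c1ccc(-c2nc(-c3nnco3)cs2)cc1`, is not yet measured. It differs from compound 1 in one place: hydrogen in place of amino on an aromatic carbon. Within the data shown here, no measured pair shows this change, so its size is unknown; a step in this assay no larger than the scatter is expected, leaning slightly downward. For compound 3 an inhibition of 14% is estimated, between 4% and 26%. The expected step is a number 4.2 percentage points lower from compound 1 to compound 3 (within the scatter).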

Compound 3, a percentage reported as inhibition, in the whole organism at one dose (the size of the read-out at that dose, not a potency): 24.2%
The estimate for compound 3 lay 10.2 percentage points below the measured number; the range from low to high includes it.
By their numbers in this assay, from the lowest: compounds 2, 1 and 3 (each within the scatter of the next).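

Taking the amino group off this aromatic carbon gives the first single-place step in this assay (a number 6 percentage points higher from compound 1 to compound 3 (within the scatter)). Because the step lies within the usual scatter, neither a gain nor a loss can be claimed, and the amino group is not shown to be needed for the inhibition seen at this dose. No measurement gives a reason for this step. On these data alone, only amino and hydrogen appear at this position, so it stays open whether a methyl group, a longer chain or a carboxylic acid there would shift the number beyond the scatter.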